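This account rests on a few compounds, and the source may have more. Where it says the series, first, only, none or still open, it means among the compounds named here.

Within the data shown here, compound 3 `CC[C@H](C)[C@H](N)CN(C(=O)[C@@H]1C[C@H]1c1c(F)cccc1F)c1ccc(-c2ccccc2)cc1` gives 11000 nM in a functional assay for agonist activity at G protein-coupled receptor 88 (Homo sapiens), read by HTRF and cAMP accumulation (a lower number here means that less compound is needed, a higher number that more compound is needed for the effect), the higher of the two numbers known here. Compound 1 `CC[C@H](C)[C@H](N)CN(C(=O)[C@@H]1C[C@H]1c1ccc(Cl)cc1)c1ccc(-c2ccccc2)cc1` gives 4300 nM, and the change from 4-chlorophenyl to 2,6-difluorophenyl brought a 2.6-fold higher number from compound 1 to compound 3 (0.41 log units; beyond the scatter). Compound 2 `CC[C@H](C)[C@H](N)CN(C(=O)[C@@H]1C[C@H]1C1CCCCC1)c1ccc(-c2ccccc2)cc1` sits at > 25000 nM, which is a limit of this assay rather than a number. Replacing 4-chlorophenyl with cyclohexyl brought an at least 5.8-fold higher number from compound 1 to compound 2 (0.76 log units; beyond the scatter), and the reverse route from cyclohexyl to 2,6-difluorophenyl gave an at least 2.2-fold lower number from compound 2 to compound 3 (0.35 log units; beyond the scatter). Compound 4 `CC[C@H](C)[C@H](N)CN(C(=O)[C@@H]1C[C@H]1c1cncnc1)c1ccc(-c2ccccc2)cc1` differs from compound 3 by pyrimidin-5-yl in place of 2,6-difluorophenyl on a saturated ring carbon. Among the measured compounds shown here, no measured step exchanges 2,6-difluorophenyl for an aromatic ring with hetero atoms, and every step that altered the group on the three-membered non-aromatic ring moved the number upward. Compound 4 is therefore expected to give 16000 nM, between 5000 nM and 40000 nM, which would be a 1.5-fold higher number from compound 3 to compound 4 (0.16 log units; within the scatter).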

Compound 4, half-maximal effective concentration: 19000 nM
Estimate against measurement, compound 4: 1.2-fold (0.07 log units) below; low and high end bracket the measured number.
By their numbers in this assay, from the lowest: compound 1; then compounds 3 and 4 (each within the scatter of the next). At a limit, above all of these: compound 2.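

Placing an aromatic ring with hetero atoms on this saturated ring carbon gives, in this assay, a 1.7-fold higher number from compound 3 to compound 4 (0.24 log units; within the scatter), so exchanging 2,6-difluorophenyl for pyrimidin-5-yl shows no clear change. Set against 4-chlorophenyl, the same ring gives a 4.4-fold higher number from compound 1 to compound 4 (0.65 log units; beyond the scatter), which leaves compound 1 with the lowest number. Cyclohexyl to pyrimidin-5-yl gives an at least 1.3-fold lower number from compound 2 to compound 4 (0.11 log units; that floor lies within the scatter), only a floor, since compound 2 stands at a limit: the limit of > 25000 nM in this assay, at which 1 of the 4 values shown sits.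

Still open, on these data alone, is whether 4-bromophenyl or pyridin-3-yl at this position would bring the number below that of compound 1. Whether a 4-chloro group is itself what sets compound 1 apart also remains unsettled.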